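This account rests on a few compounds, and the source may have more. Where it says the series, first, only, none or still open, it means among the compounds named here.

Measured so far in an in vitro assay on BHK cells for displacement of a labelled ligand from Alpha-1A adrenergic receptor (Bos taurus), read by scintillation counting, with a stated time of 20 min; a higher number here means a weaker inhibitor, a lower number a stronger inhibitor:

compound 1 `CN1CCC(c2cn(-c3ccc(F)cc3)c3ccc(-c4ccncc4)cc23)CC1` gives 10 nM
compound 2 `CN1CCC(c2cn(-c3ccncc3)c3ccc(-c4ccncc4)cc23)CC1` gives 24 nM
compound 3 `CN1CCC(c2cn(-c3ccc(F)cc3)c3ccc(-c4cccnc4)cc23)CC1` gives 2.3 nM

Two single-point changes connect these. The step of a 2.4-fold higher number from compound 1 to compound 2 (0.38 log units; beyond the scatter) goes with pyridin-4-yl in place of 4-fluorophenyl on an aromatic nitrogen. The step of a 4.3-fold lower number from compound 1 to compound 3 (0.64 log units; beyond the scatter) goes with pyridin-3-yl in place of pyridin-4-yl on an aromatic carbon. Compound 3 stands lowest of the three, with both steps to the others beyond the scatter.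

Compound 4 `CN1CCC(c2cn(-c3ccncc3)c3ccc(-c4cccnc4)cc23)CC1` is not yet measured. Its core is that of compound 3, which differs from the core of compound 1 and compound 2 only by the change just described. Compound 4 arises from compound 3 by pyridin-4-yl in place of 4-fluorophenyl on an aromatic nitrogen, and the place of this change is the same word for word as for compound 1 to compound 2, so it is the same change on the other core. Within the data shown here, a step of similar direction and size is expected in this assay, a 2.4-fold higher number from compound 3 to compound 4 (0.38 log units; beyond the scatter), resting on the single earlier occurrence of the change, a 2.4-fold higher number from compound 1 to compound 2 (0.38 log units; beyond the scatter), which is only one pair and carries no check of its transfer to the core of compound 3. For compound 4 the expected value is 5.5 nM, with an estimated range from 2.5 nM to 12 nM.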

Compound 4, inhibition constant: 22 nM
The estimate for compound 4 lay 4.0-fold (0.60 log units) below the measured number; the measured number lies above the stated range.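

In this assay, pyridin-4-yl in place of 4-fluorophenyl on an aromatic nitrogen gives a 9.6-fold higher number from compound 3 to compound 4 (0.98 log units; beyond the scatter), the same direction as on the other core but not the same size: the same change on two cores in this assay, a 2.4-fold higher number (0.38 log units; beyond the scatter) from compound 1 to compound 2 and a 9.6-fold higher number (0.98 log units; beyond the scatter) from compound 3 to compound 4, 4.0-fold (0.60 log units) apart, beyond the scatter of two such steps. Seen from the other side of the same four compounds, pyridin-3-yl in place of pyridin-4-yl on an aromatic carbon gives a 1.1-fold lower number from compound 2 to compound 4 (0.04 log units; within the scatter), so the gain seen with 4-fluorophenyl on the nitrogen does not carry over to pyridin-4-yl there: the same change on two cores in this assay, a 4.3-fold lower number (0.64 log units; beyond the scatter) from compound 1 to compound 3 and a 1.1-fold lower number (0.04 log units; within the scatter) from compound 2 to compound 4, 4.0-fold (0.60 log units) apart, beyond the scatter of two such steps. The two changes therefore do not add up independently in this set, but a single set of four compounds does not show why, nor whether this holds for any other pair of groups at these two places.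

Still open, going by these compounds, is how a plain phenyl or a pyridin-3-yl on the aromatic nitrogen would behave with either group on the aromatic carbon. Also open, on these data alone, is whether a methoxy group or an amide on that carbon, or a hydrogen in place of the methyl on the piperidine nitrogen, would show the same dependence.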